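Ester oxygen to methylene: isobutyl ketone from isobutyl ester

A few compounds are considered here, and "the series" means these few. Any claim that something is new, unique, unknown or untested is made for them only; others in the source may bear on it.

This account follows one change made to compound 1 `CC(/C=C/CC(C)CCCC(C)C)=C\C(=O)OCC(C)C`. In a physicochemical assay for lipophilicity (a higher number here means a more lipophilic compound, a lower number a more polar compound), compound 1 gives 7.69, the highest of the three numbers available. Compound 3 `C=C(C)CCCC(C)C/C=C/C(C)=C/C(=O)OCC` stands nearest to it, giving 6.19 in this assay, a value beyond the scatter below compound 1. Compound 2 `CCOC(=O)/C=C(C)/C=C/CC(C)CCC(OC)C(C)(C)OC` lies furthest away, giving 4.34 in this assay, also well beyond the scatter.

Compound 4 `CC(/C=C/CC(C)CCCC(C)C)=C\C(=O)CC(C)C` is compound 1 with isobutyl in place of isobutoxy on a carbonyl carbon; cut one bond further out, the change reads isobutoxycarbonyl to isobutylcarbonyl. Among the measured compounds shown here, no pair among the measured compounds shows this step, so nothing measured here sets its size. Taking compound 1 at 7.69 as the anchor, compound 4 is expected to move only slightly, by a number 0.11 log units higher from compound 1 to compound 4 (within the scatter) in this assay, a step that would not stand out beyond the scatter. Compound 4 is therefore estimated at 7.8 in this assay, within 7.4 to 8.3.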

Compound 4, partition coefficient: 7.22
Compound 4: the middle estimate sits 0.58 log units above what was measured; measured number below the stated range.
By their numbers in this assay, from the lowest: compound 2; then compound 3; then compound 4; then compound 1.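

Isobutyl in place of isobutoxy on a carbonyl carbon gives the first step that can be read at this position: in this assay the change runs a number 0.47 log units lower from compound 1 to compound 4 (beyond the scatter), a modest fall that stands clear of the scatter. The earlier compounds shown here included no pair differing in one place, so they gave this exchange neither a size nor a direction; now it has both, though from a single pair on the core of compound 1. Nothing available here bears on why the number moves this way.

As far as these compounds go, it remains open whether an isobutylamino group on the same carbonyl carbon would fall nearer compound 1 or compound 4. From the compounds shown here alone, it is equally open whether the step would keep its size with ethoxy, the group carried by compound 2 and compound 3, as the group that leaves.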